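The source may hold more compounds than are shown below. What is called first, only, known or untested is meant among the compounds shown, and "the series" means these compounds.

Three ureas sharing one core have been measured in a functional assay on ACHN cells (Homo sapiens) for inhibition, read by sulforhodamine B assay, with a stated time of 48 h, tested at 100 uM; on this read-out lower numbers stand for a stronger effect and higher numbers for a weaker effect at the one concentration tested. Compound 1, `COc1cc(Cl)cc(-c2nn(-c3cccc(NC(=O)Nc4ccc(Cl)c(C(F)(F)F)c4)c3)cc2-c2ccncc2)c1`, gives -31% in this assay. Compound 2, `COc1cc(Cl)cc(-c2nn(-c3cccc(NC(=O)Nc4cc(C(F)(F)F)cc(C(F)(F)F)c4)c3)cc2-c2ccncc2)c1`, gives -38% in this assay. Compound 3, `COc1cc(Cl)cc(-c2nn(-c3cccc(NC(=O)Nc4ccc(Cl)c(Cl)c4)c3)cc2-c2ccncc2)c1`, gives 6% in this assay, which is the highest of the three numbers, lying beyond the scatter from both companions. Within the data shown here, the only single-point step among the measured compounds is a number 37 percentage points higher from compound 1 to compound 3 (beyond the scatter), a large rise on this read-out.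

The next compound, compound 4, is `COc1cc(Cl)cc(-c2nn(-c3cccc(NC(=O)Nc4cccc(C(F)(F)F)c4)c3)cc2-c2ccncc2)c1`. It differs from compound 3 by 3-(trifluoromethyl)phenyl in place of 3,4-dichlorophenyl on an amide-type nitrogen. This change removes the chloro that entered in the step from compound 1 to compound 3 and places a trifluoromethyl in the position the data name for it, so that step bears on it in reverse, and compound 2, with two trifluoromethyl groups, also sits far below compound 3. Both points suggest a downward move, though compound 4 carries fewer substituents than compounds 1 and 2, which leaves the size uncertain.

For compound 4 the step of a number 26 percentage points lower from compound 3 to compound 4 (beyond the scatter) is expected, a fall of roughly the size seen before, so the estimate for compound 4 in this assay is -20%, within the range from -45% to 10%.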

Compound 4, a percentage reported as activity, at one concentration (the size of the read-out at that concentration, not a potency): -9%
Compound 4: the middle estimate sits 11 percentage points below what was measured; the measured number falls inside the stated range.
By their numbers in this assay, from the lowest: compounds 2 and 1 (each within the scatter of the next); then compound 4; then compound 3.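

In this assay, 3-(trifluoromethyl)phenyl in place of 3,4-dichlorophenyl on an amide-type nitrogen gives a number 15 percentage points lower from compound 3 to compound 4 (beyond the scatter), so a lone trifluoromethyl is enough for a lower number, with no second substituent on that aromatic ring. A second substituent still counts, however: hydrogen in place of chloro on an aromatic carbon gives a number 22 percentage points higher from compound 1 to compound 4 (beyond the scatter), and loss of the second trifluoromethyl gives a number 29 percentage points higher from compound 2 to compound 4 (beyond the scatter). Both added groups therefore go with a lower number than compound 4 shows, whereas compound 3, which carries two chloro groups and no trifluoromethyl, stands above it, and nothing measured here gives a reason for these differences.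

The compounds shown leave open how a nitrile or a carboxylic acid would read in the place held by trifluoromethyl in compound 4, and how a plain phenyl on the amide-type nitrogen would compare. They also leave open whether these steps keep their direction and size when the shared core is changed.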